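From an amide to a urea: expecting compound 4

This account rests on a few compounds, and the source may have more. Where it says the series, first, only, none or still open, it means among the compounds named here.

Compound 1 `O=C(Nc1cccc(-n2cc(-c3ccncc3)c(-c3ccc(Cl)c(O)c3)n2)c1)Nc1cccc(C(F)(F)F)c1` gives 1180 nM in a functional assay on NCI-H460 cells (Homo sapiens) for inhibition, read by sulforhodamine B assay, with a stated time of 48 h; on this read-out lower numbers stand for stronger inhibition of growth and higher numbers for weaker inhibition of growth.
Compound 2 `COc1cc(-c2nn(-c3cccc(NC(=O)Nc4cc(C(F)(F)F)cc(C(F)(F)F)c4)c3)cc2-c2ccncc2)ccc1Cl` gives 558 nM in this assay.
Compound 3 `COc1cc(-c2nn(-c3cccc(NC(=O)c4cccc(C(F)(F)F)c4)c3)cc2-c2ccncc2)ccc1Cl` gives 1450 nM in this assay.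

Compound 3 has the highest number of the three, meaning the weakest growth inhibition measured so far. Its value and that of compound 1 are within the usual scatter of each other, so nothing separates them. Compound 2 sits clearly lower, beyond the scatter, but compound 2 and compound 3 differ in more than one place, so the two values show only that the urea with two trifluoromethyl groups inhibits growth more strongly than the amide of compound 3.

Compound 4 `COc1cc(-c2nn(-c3cccc(NC(=O)Nc4ccc(Cl)c(Cl)c4)c3)cc2-c2ccncc2)ccc1Cl` has not yet been measured. It differs from compound 3 by (3,4-dichlorophenyl)amino in place of 3-(trifluoromethyl)phenyl on a carbonyl carbon. This turns the amide into a urea, the same connecting unit seen in compound 1 and compound 2, while the aryl ring carries two chlorines instead of one trifluoromethyl. The step of a 1.9-fold lower number from compound 3 to compound 4 (0.29 log units; within the scatter) is expected to be a modest move toward stronger inhibition, perhaps not beyond the scatter, since compound 1 gives 1180 nM and compound 2 gives 558 nM, both of them ureas. Compound 4 is therefore expected to give about 750 nM, in the range 300 nM to 2000 nM.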

Compound 4, concentration for 50% growth inhibition: 1110 nM
Compound 4: the middle estimate sits 1.5-fold (0.17 log units) below what was measured; the range from low to high includes it.
By their numbers in this assay, from the lowest: compounds 2, 4, 1 and 3 (each within the scatter of the next, the first and the last beyond it).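

For the compounds shown here, this is the first direct comparison at this position: on a carbonyl carbon, (3,4-dichlorophenyl)amino replaces 3-(trifluoromethyl)phenyl, which turns the amide into a urea and changes the groups on the aryl ring in a single move. In this assay the result is a 1.3-fold lower number from compound 3 to compound 4 (0.12 log units; within the scatter), so this exchange, in which the entering group carries a hydrogen-bond donor and the leaving group carries none, gives no measurable difference in growth inhibition for this pair. No measurement shown here accounts for this outcome, and it remains a plain observation about these two compounds.

The urea unit and the two chlorines change together in this step, so their separate contributions cannot be read from it, and any effect of one could be hidden by an opposite effect of the other. As far as these compounds go, it also remains open how growth inhibition responds when the aryl ring at this position gives way to a non-aromatic group such as cyclohexyl, or when that ring carries a carboxylic acid.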